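The compounds below may be only part of what the source reports. "The series", "measured", "known", "first", "only" and "open" are said of these compounds alone.

Within the data shown here, compound 2 `COc1cccc(/C=C/C(=O)Nc2cc(C(=O)c3cc(OC)c(OC)c(OC)c3)ccc2OC)c1` stands second highest of the three numbers so far in a functional assay on DU-145 cells (Homo sapiens) for cytotoxicity, read by MTT assay, with a stated time of 72 h (a higher number here means a weaker inhibitor, a lower number a stronger inhibitor), giving 6200 nM. Its nearest neighbour is compound 3 `COc1cc(/C=C/C(=O)Nc2cc(C(=O)c3cc(OC)c(OC)c(OC)c3)ccc2OC)ccc1F`, which gives 12100 nM in this assay; the furthest is compound 1 `COc1ccc(C(=O)c2cc(OC)c(OC)c(OC)c2)cc1N`, which in this assay gives 2100 nM, a number beyond the scatter from compound 2. The step to compound 4 `COc1ccc(C(=O)c2cc(OC)c(OC)c(OC)c2)cc1NC(=O)/C=C/c1ccc(N)cc1` is 4-aminophenyl in place of 3-methoxyphenyl on a double-bonded chain carbon bound to a double-bonded chain carbon. Among the measured compounds shown here, the one measured step, a 2.0-fold higher number from compound 2 to compound 3 (0.29 log units; within the scatter), concerns a change at a different place and lies within the scatter, so no measured step bears directly on the exchange of the 3-methoxyphenyl group. The gap between compound 2 and compound 1 shows that removing the whole cinnamoyl chain lowers the number, but this does not tell how a changed aryl group on that chain will read. On these grounds compound 4 is expected to show no step beyond the scatter, estimated at 5000 nM with a range from 1500 nM to 16000 nM. The step from compound 2 to compound 4 that this estimate means is expected to be a 1.2-fold lower number from compound 2 to compound 4 (0.09 log units; within the scatter).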

Compound 4, half-maximal inhibitory concentration: 13500 nM
Compound 4: the middle estimate sits 2.7-fold (0.43 log units) below what was measured; the measured number falls inside the stated range.
By their numbers in this assay, from the lowest: compound 1; then compounds 2, 3 and 4 (each within the scatter of the next, the first and the last beyond it).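

In this assay, among these compounds, the exchange of 3-methoxyphenyl for 4-aminophenyl gives the first step beyond the scatter at this place on the chain, a 2.2-fold higher number from compound 2 to compound 4 (0.34 log units; beyond the scatter), though a modest one. The exchange from 4-fluoro-3-methoxyphenyl gives no such separation, with a 1.1-fold higher number from compound 3 to compound 4 (0.05 log units; within the scatter), so these two aryl groups cannot be told apart here. Placing the (2-(4-aminophenyl)ethenyl)carbonyl group on the nitrogen in place of hydrogen gives a 6.4-fold higher number from compound 1 to compound 4 (0.81 log units; beyond the scatter), so compound 1, with its free amine, keeps the lowest number, and compound 4 does not close that gap.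

No measurement offered here explains these steps. Going by these compounds, it remains open how a hydroxyl group, a dimethylamino group or a carboxylic acid in place of the amine of the 4-aminophenyl group would read.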